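Ring-nitrogen substituent: hydroxyl end to carboxy end

This account rests on a few compounds, and the source may have more. Where it says the series, first, only, none or still open, it means among the compounds named here.

Measured so far:
compound 1 `Cn1c(Cc2nn(C)c(=O)c3ccccc23)nnc1SCCCCCCCC(=O)Nc1ccc(Cl)cc1Cl`: 350 nM
compound 2 `Cn1c(Cc2nn(CCCO)c(=O)c3ccccc23)nnc1SCCCCCCCC(=O)Nc1ccc(Cl)cc1Cl`: > 30000 nM

In an assay on NK92 cells for inhibition of interleukin-2 (Homo sapiens), read by AlphaScreen, with stated times of 30 min and 1 h (on this read-out lower numbers stand for stronger inhibition and higher numbers for weaker inhibition), compound 1 gives 350 nM. For compound 2 this assay reports only a limit, > 30000 nM. That limit is the limit of > 30000 nM in this assay, at which 1 of the 2 values shown sits, and not a measured number. The step of an at least 85-fold higher number from compound 1 to compound 2 (1.93 log units; beyond the scatter) thus places compound 2 at the weak end of the two numbers shown.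

Compound 3 `Cn1c(Cc2nn(CCC(=O)O)c(=O)c3ccccc23)nnc1SCCCCCCCC(=O)Nc1ccc(Cl)cc1Cl` keeps the substituent on the aromatic nitrogen and alters only its terminus: carboxy in place of hydroxymethyl on a saturated chain carbon, two bonds along the chain from an aromatic nitrogen. Among the measured compounds shown here, no measured step covers a change of this kind. For the measured compounds named here, the only step available, an at least 85-fold higher number from compound 1 to compound 2 (1.93 log units; beyond the scatter), concerns the addition of the side chain itself and says nothing about its terminal group. Compound 3 is therefore expected to remain near the limit. The step of a number no higher from compound 2 to compound 3 (the limit leaves the size open) is expected to stay within the scatter. The estimated value for compound 3 is 30000 nM, with a range of 6000 nM to 100000 nM.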

Compound 3, half-maximal inhibitory concentration: 30000 nM
The estimate for compound 3 equals the measured number at the digits printed, and the stated range covers the measured number.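

Compound 3 gives the series its first measured number for a longer chain on the aromatic nitrogen, so the loss against the methyl of compound 1 now has a size, with an 86-fold higher number from compound 1 to compound 3 (1.93 log units; beyond the scatter) as the measured step. Weak inhibition is therefore not confined to the chain with the hydroxyl end, as the carboxy end on the same chain also stands far from compound 1. For a number no higher from compound 2 to compound 3 (the limit leaves the size open) the size cannot be read, because compound 2 stands only at a limit: the limit of > 30000 nM in this assay, at which 1 of the 3 values shown sits.

Open, on these data alone, is whether the loss goes with the chain itself or with its end group; a plain propyl chain, or the same chain ending in an amine, would separate the two. Also open, as far as these compounds go, is how an ethyl group on that nitrogen compares with the methyl of compound 1.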